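A few compounds are considered here, and "the series" means these few. Any claim that something is new, unique, unknown or untested is made for them only; others in the source may bear on it.

Measured so far: compound 2 `COc1ccc(/C=C(\Cl)C(=O)Nn2c(C)nc3ccccc3c2=O)cc1` gives 900 nM; compound 1 `Cc1nc2ccccc2c(=O)n1NC(=O)/C(Cl)=C/c1ccccc1` gives 30 nM.

Among the compounds with values here, in a functional assay on MCF7 cells (Homo sapiens) for inhibition, read by sulforhodamine B assay, with a stated time of 48 h (a higher number here means a weaker inhibitor of growth, a lower number a stronger inhibitor of growth), compound 2 stands with the higher of the two numbers; the only step that reaches it, a 30-fold higher number from compound 1 to compound 2 (1.48 log units; beyond the scatter), shows how much a methoxy in place of hydrogen raised the number. Compound 3 `Cc1nc2ccccc2c(=O)n1NC(=O)/C(Cl)=C/c1ccc(Cl)cc1` is not yet measured; it differs from compound 2 by chloro in place of methoxy on an aromatic carbon. Within the data shown here, no step that exchanges one substituent for another has been measured here, so only the single step bears on it. Since compound 2 moved far from compound 1 and a chloro is neither hydrogen nor methoxy, the estimate for compound 3 is 250 nM, with a range from 40 nM to 1500 nM, meaning an expected step of a 3.6-fold lower number from compound 2 to compound 3 (0.56 log units; beyond the scatter).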

Compound 3, concentration for 50% growth inhibition: 70600 nM
Compound 3: the middle estimate sits 280-fold (2.45 log units) below what was measured; the whole stated range lies below it.
By their numbers in this assay, from the lowest: compound 1; then compound 2; then compound 3.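

In this assay the exchange of 4-methoxyphenyl for 4-chlorophenyl gives a 78-fold higher number from compound 2 to compound 3 (1.89 log units; beyond the scatter) and so shows that these two substituents at this place are far from interchangeable. Chloro in place of hydrogen gives a 2400-fold higher number from compound 1 to compound 3 (3.37 log units; beyond the scatter) and goes further than methoxy did, so both groups raise the number here and compound 1, with hydrogen at this place, keeps the lowest. Nothing measured here explains this difference.

The compounds shown leave open whether a fluoro or an amine at this place would stay near compound 1. They also leave open whether a hydroxyl would track methoxy.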